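Fluorine on the Aromatic Ring and Tolerated Concentration

This account rests on a few compounds, and the source may have more. Where it says the series, first, only, none or still open, it means among the compounds named here.

Measured compounds:
compound 1, `CC[C@@H](CCn1cncn1)c1ccccc1`: 91.2 ug/mL
compound 2, `CC[C@@H](CCn1cncn1)c1ccc(F)cc1`: 91.6 ug/mL
compound 3, `CCC[C@H](CCn1cncn1)c1ccccc1`: 63.1 ug/mL

In an ADME assay on RD cells (Homo sapiens) for cytotoxicity, read by MTT assay, with a stated time of 3 days (a higher number here means that more compound is tolerated, a lower number that less compound is tolerated), compound 1 gives 91.2 ug/mL and compound 2 gives 91.6 ug/mL. The step of a 1.0-fold higher number from compound 1 to compound 2 (0.00 log units; within the scatter) belongs to the change (fluoro in place of hydrogen on an aromatic carbon). Compound 3 gives 63.1 ug/mL in this assay; the difference between its core and the core of compound 1 is not broken down here. Compound 4, `CCC[C@H](CCn1cncn1)c1ccc(F)cc1`, carries the same change, (fluoro in place of hydrogen on an aromatic carbon), the second of two occurrences among these compounds. The step from compound 3 to compound 4 is expected to be a 1.0-fold lower number from compound 3 to compound 4 (0.00 log units; within the scatter) in this assay, because the earlier step of a 1.0-fold higher number from compound 1 to compound 2 (0.00 log units; within the scatter) stayed within the scatter. Compound 4 is therefore estimated at 63 ug/mL in this assay, expected to fall between 40 ug/mL and 100 ug/mL.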

Compound 4, half-maximal cytotoxic concentration: 38.4 ug/mL
Estimate against measurement, compound 4: 1.6-fold (0.22 log units) above, and the stated range ends above it.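

In this assay, fluoro in place of hydrogen on an aromatic carbon gives a 1.6-fold lower number from compound 3 to compound 4 (0.22 log units; within the scatter), and the two cores do not differ in their response to this change: the same change on two cores in this assay, a 1.0-fold higher number (0.00 log units; within the scatter) from compound 1 to compound 2 and a 1.6-fold lower number (0.22 log units; within the scatter) from compound 3 to compound 4, 1.7-fold (0.22 log units) apart, within the scatter of two such steps. Within these two pairs, then, the change carries from one core to the other without a step beyond the scatter, and neither core can be said to respond differently. Among the compounds shown here, this does not show that the same would hold on other cores, since only two pairs bear on it, and it gives no reason for the result.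

From the compounds shown here alone, whether a chloro group, a methoxy group or an amine at that same place would behave like fluoro remains open. So does the effect of a longer chain on the shared core.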